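The compounds below may be only part of what the source reports. "The series", "measured", "known", "first", "only" and "open" are said of these compounds alone.

Measured compounds, with their values in a functional assay on the whole organism (strain Sprague-Dawley) for inhibition, with Rattus norvegicus as the target; a lower number here means that less compound is needed, a higher number that more compound is needed for the effect:

- compound 1, `CCc1ccc2c(=O)c(-c3nn[nH]n3)c[nH]c2c1`, gives > 10 mg/kg; this is a limit of the assay, not a number.
- compound 2, `O=c1c(-c2nn[nH]n2)c[nH]c2ccccc12`, gives > 20 mg/kg; again a limit.
- compound 3, `O=c1c(-c2nn[nH]n2)c[nH]c2ccc(F)cc12`, gives > 20 mg/kg; again a limit.

Compound 2 thus stands only at a limit in this assay, and the two further values shown are limits as well: the three values divide between the limit of > 10 mg/kg in this assay, at which 1 of the 3 values shown sits, and (the limit of > 20 mg/kg in this assay, at which 2 of the 3 values shown sit). For the measured compounds named here, no compound in the set has a numeric reading, so no compound can be set above or below another.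

Compound 4, `CC(C)Oc1cccc2c(=O)c(-c3nn[nH]n3)c[nH]c12`, differs from compound 2 by isopropoxy in place of hydrogen on an aromatic carbon. The two measured steps that touch compound 2 are a step that the two limits leave unreadable from compound 1 to compound 2 and a step that the two limits leave unreadable from compound 2 to compound 3; both run between limits, so neither has a readable size, and neither concerns an isopropoxy group. Going by the values given here, there is therefore no measured step from which a size or a direction for the change to compound 4 can be taken. The working expectation is that compound 4 stays where the measured members of the series sit, with the result most likely being reported as a limit rather than a number.

On that basis compound 4 is estimated at 20 mg/kg, expected between 5 mg/kg and 40 mg/kg, which would mean a step of a number no higher from compound 2 to compound 4 (the limit leaves the size open), not beyond the scatter.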

Compound 4, minimum effective dose: 1.25 mg/kg
The estimate for compound 4 lay 16-fold (1.20 log units) above the measured number; measured number below the stated range.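

In this assay, for the compounds shown here, isopropoxy in place of hydrogen on an aromatic carbon, ortho to a fused ring and meta to a fused ring, gives an at least 16-fold lower number from compound 2 to compound 4 (1.20 log units; beyond the scatter), which makes this change the first with a readable size and places compound 4 as the only compound here with a numeric reading. The steps that join compound 1, compound 2 and compound 3 run between limits and cannot be read, so ethyl and fluoro offer no size to set against this one, and the isopropoxy step stands alone as evidence that a substitution on this ring of the shared core can move the series off its limits. The values shown include no measured property that bears on this step.

Open, on these data alone, is whether the change depends on isopropoxy itself or would also appear with a methoxy, a hydroxyl, an amine or a longer alkoxy chain at the same carbon. Also open, as far as these compounds go, is whether isopropoxy on another carbon of the same ring, or a carboxylic acid in place of the tetrazole in compound 4, would hold the reading of compound 4.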